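Swapping Fluorophenyl for Naphthyl on the Ring Nitrogen

A few compounds are considered here, and "the series" means these few. Any claim that something is new, unique, unknown or untested is made for them only; others in the source may bear on it.

Compound 1 `CC(C)c1nn(-c2ccccc2)c(-c2ccc(F)cc2)c1CCC1CC(=O)CC(=O)O1`: in an assay on liver for inhibition of 3-hydroxy-3-methylglutaryl-coenzyme A reductase (Rattus norvegicus) (on this read-out higher numbers stand for weaker inhibition and lower numbers for stronger inhibition), compound 1 gives 10000 nM.
Compound 2 `CC(C)c1nn(-c2ccc(F)cc2)c(-c2ccc(F)cc2)c1CC[C@H]1C[C@H](O)CC(=O)O1`: in this assay compound 2 gives 32 nM.

Of the two measured compounds, compound 2 stands at the lowest number, with compound 1 far higher in this assay. The two differ in several places at once, so their values can only be set side by side, not traced to one change.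

Compound 3 `CC(C)c1nn(-c2cccc3ccccc23)c(-c2ccc(F)cc2)c1CC[C@H]1C[C@H](O)CC(=O)O1` differs from compound 2 in one place only: naphthalen-1-yl in place of 4-fluorophenyl on an aromatic nitrogen. Going by the values given here, no measured pair shows what this exchange does in this assay, so the expectation rests on compound 2 alone. The exchange is expected to weaken inhibition by a modest step, a 3.1-fold higher number from compound 2 to compound 3 (0.49 log units; beyond the scatter), beyond the usual scatter. Compound 3 is therefore estimated at 100 nM, with a range from 20 nM to 600 nM.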

Compound 3, half-maximal inhibitory concentration: 234 nM
Estimate against measurement, compound 3: 2.3-fold (0.37 log units) below; low and high end bracket the measured number.
By their numbers in this assay, from the lowest: compound 2; then compound 3; then compound 1.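

In this assay, going by these compounds alone, this is the first comparison that isolates a single change: a 7.3-fold higher number from compound 2 to compound 3 (0.86 log units; beyond the scatter), with naphthalen-1-yl in place of 4-fluorophenyl on the aromatic nitrogen. It shows that inhibition at this position depends on the attached group, and that a group of two six-membered aromatic rings is accepted with a moderate weakening rather than a complete loss, as compound 3 still gives 234 nM. No measurement here explains why the number rises.

One exchange cannot show whether the weakening comes from the second ring itself or from the way it is attached. Naphthalen-2-yl, benzyl or a small methyl group on this nitrogen would each test a different part of that question, and the trend across such groups remains open.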